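A few compounds are considered here, and "the series" means these few. Any claim that something is new, unique, unknown or untested is made for them only; others in the source may bear on it.

Measured compounds:
Compound 1 `O=c1[nH]c2ncn(Cc3ccncc3)c2c(=O)n1O` — 245000 nM
Compound 2 `O=c1[nH]c2ncn(C3CCCCC3)c2c(=O)n1O` — "not determined" (no result reported)

The set contains two measured compounds with a shared core. Among the measured compounds shown here, in an assay on isolated protein for inhibition of poly(A)-specific ribonuclease PARN (Homo sapiens) (on this read-out higher numbers stand for weaker inhibition and lower numbers for stronger inhibition), compound 1 gives 245000 nM, and this is the only number; for compound 2 no result was obtained in this assay, so nothing can be said of its inhibition. Compound 1 therefore stands alone, without any measured neighbour to set the size of a structural step against.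

Compound 3 `O=c1[nH]c2ncn(Cc3ccccc3)c2c(=O)n1O` differs from compound 1 in one place: phenyl in place of pyridin-4-yl on a saturated chain carbon bound to an aromatic nitrogen. For the measured compounds named here, no measured pair shows what such an exchange does on this read-out, so the direction of the step is open. With nothing to point either way, the expected step is none beyond the usual scatter, and compound 3 is estimated to sit close to compound 1, the estimated step from compound 1 to compound 3 being a 1.1-fold lower number from compound 1 to compound 3 (0.05 log units; within the scatter). On that basis compound 3 is expected to give 220000 nM in this assay, with a range from 60000 nM to 800000 nM, and a real chance that only a limit is reported.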

Compound 3, half-maximal inhibitory concentration: 84100 nM
For compound 3 the middle estimate is 2.6-fold (0.42 log units) above the measured one; the range from low to high includes it.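

In this assay, the exchange of pyridin-4-yl for phenyl on a saturated chain carbon bound to an aromatic nitrogen gives the series its first readable step, a 2.9-fold lower number from compound 1 to compound 3 (0.46 log units; beyond the scatter), a modest change that lies beyond the scatter. It shows that this position is not indifferent to the ring it carries: the number moves even though the ring stays six-membered and aromatic, and the ring of carbon only goes with the lower number, so stronger inhibition. Nothing at hand explains this step, and it stands here as an observation alone.

This single pair does not show whether the same exchange would act alike on another core, nor whether it would hold for any other ring at this position. Going by these compounds, it also remains open whether a phenyl carrying a chlorine atom or a carboxylic acid, or a longer chain leading to the phenyl, would move the number further on this read-out.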